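The compounds below may be only part of what the source reports. "The series", "measured", "known", "first", "only" and "open" are said of these compounds alone.

Compound 2 `COC(=O)c1cccc(Cl)c1OC(=O)COc1cc(O)c2c(=O)cc(-c3ccccc3)oc2c1` gives 38700 nM in a functional assay on cells (T-cell, Mus musculus, strain BALB/c) for inhibition, read by MTT assay, with a stated time of 72 h (a higher number here means a weaker inhibitor, a lower number a stronger inhibitor), the higher of the two numbers measured; compound 1 `COC(=O)c1cc(Cl)ccc1OC(=O)COc1cc(O)c2c(=O)cc(-c3ccccc3)oc2c1` gives 3740 nM. Within the data shown here, the only measured step, a 10-fold higher number from compound 1 to compound 2 (1.01 log units; beyond the scatter), is large. Compound 3 `COC(=O)c1cc(F)ccc1OC(=O)COc1cc(O)c2c(=O)cc(-c3ccccc3)oc2c1` differs from compound 2 by a group of 11 heavy atoms (8 carbon, 2 oxygen, 1 fluorine; one six-membered aromatic ring of carbon only) in place of a group of 11 heavy atoms (8 carbon, 2 oxygen, 1 chlorine; one six-membered aromatic ring of carbon only), on an oxygen next to a carbonyl group; the entering group matches that of compound 1 except for fluorine in place of chlorine, so the step mostly reverses the measured one. A lower number is therefore expected for compound 3, with an estimated step of an 8.6-fold lower number from compound 2 to compound 3 (0.93 log units; beyond the scatter). For compound 3 the estimate in this assay is 4500 nM, within 1500 nM to 14000 nM.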

Compound 3, half-maximal inhibitory concentration: 6820 nM
Estimate against measurement, compound 3: 1.5-fold (0.18 log units) below, and the stated range covers the measured number.
By their numbers in this assay, from the lowest: compounds 1 and 3 (each within the scatter of the next); then compound 2.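

In this assay, fluoro in place of chloro on an aromatic carbon gives a 1.8-fold higher number from compound 1 to compound 3 (0.26 log units; within the scatter), so at this site the two halogens are not told apart. The fluorine-bearing group also gives a 5.7-fold lower number from compound 2 to compound 3 (0.75 log units; beyond the scatter), which leaves 2-chloro-6-(methoxycarbonyl)phenyl apart from the other two groups on the oxygen next to a carbonyl group, and the halogen alone does not account for that gap. No measurement available here explains these differences. Going by these compounds, whether bromo behaves like these halogens remains open, as does the effect of a carboxylic acid in place of the methoxycarbonyl group.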